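Cyclopentyl in place of isopropyl: what to expect

This account rests on a few compounds, and the source may have more. Where it says the series, first, only, none or still open, it means among the compounds named here.

Measured in an assay on isolated protein for inhibition of tyrosine-protein kinase receptor UFO (Homo sapiens), read by FRET and Z'-LYTE, with a stated time of 1.5 h; a lower number here means a stronger inhibitor, a higher number a weaker inhibitor:
Compound 1 `Cc1c(C(=O)Nc2ccc(Oc3ncnc4[nH]cc(-c5ccccc5)c34)c(F)c2)c(=O)c2ccccc2n1C` gives > 10000 nM, which is a limit of the assay.
Compound 2 `Cc1c(C(=O)Nc2ccc(Oc3ncnc4[nH]cc(-c5ccccc5)c34)c(F)c2)c(=O)c2cc(Br)ccc2n1C` gives 3120 nM.
Compound 3 `Cc1c(C(=O)Nc2ccc(Oc3ncnc4[nH]cc(-c5ccccc5)c34)c(F)c2)c(=O)c2cc(C(C)C)ccc2n1C` gives 26 nM.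

Compound 3 stands lowest of the two numbers, and its nearest neighbour is compound 2, with the step of a 120-fold lower number from compound 2 to compound 3 (2.08 log units; beyond the scatter) lying beyond the scatter. Compound 1 sits at the limit of > 10000 nM in this assay, at which 1 of the 3 values shown sits. Compound 4 `Cc1c(C(=O)Nc2ccc(Oc3ncnc4[nH]cc(-c5ccccc5)c34)c(F)c2)c(=O)c2cc(C3CCCC3)ccc2n1C` differs from compound 3 by cyclopentyl in place of isopropyl on an aromatic carbon. For the measured compounds named here, the steps that bear on this position are an at least 3.2-fold lower number from compound 1 to compound 2 (0.50 log units; beyond the scatter), an at least 380-fold lower number from compound 1 to compound 3 (2.58 log units; beyond the scatter) and a 120-fold lower number from compound 2 to compound 3 (2.08 log units; beyond the scatter): among compounds 1, 2 and 3, the isopropyl group gave by far the lowest number. A cyclopentyl group has not been measured here, so compound 4 is expected to land near compound 3, estimated at 30 nM with a range from 8 nM to 120 nM. The expected step of a 1.2-fold higher number from compound 3 to compound 4 (0.06 log units; within the scatter) is therefore within the scatter.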

Compound 4, half-maximal inhibitory concentration: 200 nM
Estimate against measurement, compound 4: 6.7-fold (0.82 log units) below; the measured number lies above the stated range.
By their numbers in this assay, from the lowest: compound 3; then compound 4; then compound 2. At a limit, above all of these: compound 1.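

In this assay, the isopropyl group proves not to be interchangeable with a larger carbon-only group at this aromatic carbon: a 7.7-fold higher number from compound 3 to compound 4 (0.89 log units; beyond the scatter). Cyclopentyl still stands well clear of the bromo and hydrogen compounds, with a 16-fold lower number from compound 2 to compound 4 (1.19 log units; beyond the scatter) and an at least 50-fold lower number from compound 1 to compound 4 (1.69 log units; beyond the scatter). Compound 1 stands at a limit of the assay, so the last step has only a bound: the limit of > 10000 nM in this assay, at which 1 of the 4 values shown sits.

The compounds shown leave open whether the ring itself or the added carbons account for the loss against compound 3. On these data alone, a cyclopropyl or tert-butyl group would bear on this, and an amine or a methoxy group at the same carbon also remains open.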